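Fluoro for Methyl on the Terminal Aryl Ring

A few compounds are considered here, and "the series" means these few. Any claim that something is new, unique, unknown or untested is made for them only; others in the source may bear on it.

The series rests on three measured compounds. Compound 1 `O=C1Nc2ccc(Br)cc2/C1=N/NC(=S)N1CCN(c2ccccc2)CC1` gives 20500 nM in a functional assay on MCF7 cells (Homo sapiens) for inhibition, read by MTT assay, with a stated time of 72 h (a higher number here means a weaker inhibitor, a lower number a stronger inhibitor), and compound 2 `O=C1Nc2cc(Br)ccc2/C1=N/NC(=S)N1CCN(c2ccccc2)CC1` gives 19700 nM in this assay. Compound 3 `Cc1ccccc1N1CCN(C(=S)N/N=C2\C(=O)Nc3ccc(Cl)cc32)CC1` gives 10900 nM in this assay, which is the lowest of the three numbers, though its distance to compound 2 and to compound 1 is within the scatter, so no order among the three can be read from these values.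

Compound 4 `O=C1Nc2ccc(Cl)cc2/C1=N/NC(=S)N1CCN(c2ccccc2F)CC1` has not been measured. It differs from compound 3 by fluoro in place of methyl on an aromatic carbon. For the measured compounds named here, no pair among the measured compounds shows this exchange, so there is no measured step to lean on.

Going by the values given here, with only this small exchange of one substituent for another, and with the three measured values lying so close together in this assay, the step from compound 3 to compound 4 is expected to stay within the scatter, without a clear direction. On that basis compound 4 is estimated at 13000 nM in this assay, with a range from 4500 nM to 38000 nM, which corresponds to an expected step of a 1.2-fold higher number from compound 3 to compound 4 (0.08 log units; within the scatter).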

Compound 4, half-maximal inhibitory concentration: 15200 nM
Compound 4: middle estimate off by 1.2-fold (0.07 log units), on the low side; measured number inside the range.
By their numbers in this assay, from the lowest: compounds 3, 4, 2 and 1 (each within the scatter of the next).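

For the compounds shown here, this is the first measured step, and it falls on the terminal aryl ring: in this assay, going from 2-methylphenyl to 2-fluorophenyl gives a 1.4-fold higher number from compound 3 to compound 4 (0.14 log units; within the scatter) and so adds a single reading of this exchange to three values that until now could only be set side by side. On an aromatic carbon ortho to a large group, then, methyl and fluoro cannot be told apart by this read-out, and one heavy atom can be replaced by another here without a difference that can be read. Nothing measured on these compounds bears on why the two groups read alike, and the result gives no direction for this exchange.

The compounds shown leave open whether any group at this place would separate from methyl and fluoro, such as a methoxy, a trifluoromethyl, an amine or a carboxylic acid, or plain hydrogen in a compound otherwise identical to compound 3. They also leave open whether the same exchange of methyl for fluoro would read alike on a core carrying bromo in place of chloro.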